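A few compounds are considered here, and "the series" means these few. Any claim that something is new, unique, unknown or untested is made for them only; others in the source may bear on it.

Measured compounds:
Compound 1, `CCC(=O)N1N=C(c2ccc(C)cc2)CC1c1cn(-c2ccccc2)nc1-c1ccc(Cl)c(Cl)c1`: 61.1%
Compound 2, `O=CN1N=C(c2ccc(F)cc2)CC1c1cn(-c2ccccc2)nc1-c1ccc(Cl)c(Cl)c1`: 56.5%
Compound 3, `CC(=O)N1N=C(c2ccc(C)cc2)CC1c1cn(-c2ccccc2)nc1-c1ccc(Cl)c(Cl)c1`: 59.5%

All three were tested in a functional assay on the whole organism (strain Wistar) for inhibition, with Rattus norvegicus as the target, read by paw edema, with stated times of 30 min and 60 min, at a dose of 50 mg/kg by the oral route; on this read-out lower numbers stand for less inhibition and higher numbers for more inhibition at the one dose given (going by the name of the read-out). On the numbers shown, compound 2 does not stand apart from the other two: its gap to compound 3 and its gap to compound 1 both fall within the usual scatter of this measurement, so the three values cannot be ranked.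

Compound 4, `Fc1ccc(C2=NN(c3ccccc3)C(c3cn(-c4ccccc4)nc3-c3ccc(Cl)c(Cl)c3)C2)cc1`, has not yet been measured. It is derived from compound 2 by one change, (phenyl in place of formyl on an amine nitrogen in a ring). Going by the values given here, only one measured step exists for comparison, a number 1.6 percentage points lower from compound 1 to compound 3 (within the scatter), and it concerns the group on the carbonyl rather than the ring nitrogen itself; it was within the scatter. Among the compounds with values here, no measured pair varies the substituent on that ring nitrogen, and no pair exchanges a formyl for a phenyl anywhere, so the step to compound 4 has no direct precedent. Given that the only variation seen at this end of the molecule left this assay unchanged, the step of a number 0.5 percentage points higher from compound 2 to compound 4 (within the scatter) is expected to stay within the scatter, with a wider uncertainty because the change is larger. Compound 4 is therefore estimated at 57%, within a range from 42% to 70%.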

Compound 4, a percentage reported as inhibition, in the whole organism at one dose (the size of the read-out at that dose, not a potency): 55.7%
Beside the measured number, compound 4's estimate is 1.3 percentage points above it; the range from low to high includes it.
By their numbers in this assay, from the lowest: compounds 4, 2, 3 and 1 (each within the scatter of the next).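

In this assay, going by these compounds alone, the step of a number 0.8 percentage points lower from compound 2 to compound 4 (within the scatter) shows that this position accepts a far larger exchange than the earlier compounds covered, with the number staying within the scatter. Compounds 1, 2 and 3 all carry a carbonyl on the amine nitrogen in the ring and differ at most in the small group attached to it, whereas compound 4 has no carbonyl there and bears a phenyl, a six-membered aromatic ring of 6 heavy atoms, in place of the 2 heavy atoms of formyl. No measurement at hand speaks to the reason for this result.

The compounds shown leave open whether a group of another kind on that ring nitrogen, such as a chain ending in an amine or in a carboxylic acid, would also stay within the scatter. They also leave open whether phenyl behaves the same way on the core of compound 1, and whether the similarity at this one oral dose would hold at other doses.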